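Phenyl for Ethoxycarbonyl on the Imine Carbon

The compounds below may be only part of what the source reports. "The series", "measured", "known", "first", "only" and "open" are said of these compounds alone.

Measured so far in a functional assay on HeLa cells (Homo sapiens) for antiproliferative activity, read by MTT assay; a higher number here means a weaker inhibitor, a lower number a stronger inhibitor:
Compound 1, `CCOC(=O)/C=N/c1cnc(Nc2ccc(N3CCN(C)CC3)cc2)nc1NC1CCCC1`: 19000 nM
Compound 2, `CN1CCN(c2ccc(Nc3ncc(/N=C/c4ccccc4)c(NC4CCCC4)n3)cc2)CC1`: > 100000 nM, a limit of this assay
Compound 3, `CCOC(=O)/C=N/c1cnc(Nc2ccc(S(N)(=O)=O)cc2)nc1NC(C)C`: 83300 nM

Compound 2 differs from compound 1 by phenyl in place of ethoxycarbonyl on a carbon with a double bond to nitrogen, and that change brought an at least 5.2-fold higher number from compound 1 to compound 2 (0.72 log units; beyond the scatter). Compound 3 gives the highest of the two numbers. Compound 2 gives only a limit, > 100000 nM. How the core of compound 3 differs from that of compound 1 is not broken down here.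

Compound 4, `CC(C)Nc1nc(Nc2ccc(S(N)(=O)=O)cc2)ncc1/N=C/c1ccccc1`, has not been measured. It differs from compound 3 by phenyl in place of ethoxycarbonyl on a carbon with a double bond to nitrogen, the same change at the same place. The step from compound 3 to compound 4 is expected to be a 4.2-fold higher number from compound 3 to compound 4 (0.62 log units; beyond the scatter), resting on the earlier step of an at least 5.2-fold higher number from compound 1 to compound 2 (0.72 log units; beyond the scatter) and on compound 3 already standing close to the limit (the limit of > 100000 nM in this assay, at which 1 of the 3 values shown sits). Compound 4 is therefore expected at about 350000 nM, and most likely this assay will report only a limit for it.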

Compound 4, half-maximal inhibitory concentration: > 100000 nM
Compound 4: a limit, no number; the forecaster's own chance of this, stated with the estimate: 85%; the middle value is on the limit's open side.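

In this assay compound 4 gives > 100000 nM, which is a limit and not a number. Phenyl in place of ethoxycarbonyl gives an at least 1.2-fold higher number from compound 3 to compound 4 (0.07 log units; that floor lies within the scatter), so the change again goes with no fall in the number, but this floor alone does not show a real change on this core, and the true size of the step stays unknown. Whether the change carries over from one core to the other with the same size can be said only this far: the same change on two cores in this assay, an at least 5.2-fold higher number (0.72 log units; beyond the scatter) from compound 1 to compound 2 and an at least 1.2-fold higher number (0.07 log units; that floor lies within the scatter) from compound 3 to compound 4; the limit leaves it open whether they differ.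

From the compounds shown here alone, it remains open how a carboxylic acid or a primary amide in place of ethoxycarbonyl, on a carbon with a double bond to nitrogen, would read in this assay.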